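Switching the Aryl Group of Compound 2 for Compound 4

The source may report more compounds than this note shows. Statements on the series, on what has been measured and on what is new or still open speak of the compounds shown alone.

Measured so far:
compound 1 `COc1ccc(/C=N/NC(=O)c2cc(OC)c(OC)c(OC)c2)c(OC)c1`: 3.6%
compound 2 `COc1cc(C2=NN(C(C)=O)C(c3c(Cl)cccc3Cl)O2)cc(OC)c1OC`: 15.9%
compound 3 `COc1cc(/C=N/NC(=O)c2cc(OC)c(OC)c(OC)c2)cc(OC)c1OC`: 22.9%

In a functional assay on BGC-823 cells (Homo sapiens) for antiproliferative activity, read by MTT assay, tested at 5 uM (a lower number here means a weaker effect, a higher number a stronger effect of the compound at the concentration tested), compound 2 gives 15.9% and stands second highest of the three numbers. Its nearest neighbour is compound 3 with 22.9%, a value that lies within the usual scatter of compound 2, so no order between the two can be claimed. Compound 1 gives 3.6%, a number that lies beyond the scatter below compound 2.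

Compound 4 `COc1cc(C2=NN(C(C)=O)C(c3ccc(C(F)(F)F)cc3)O2)cc(OC)c1OC` differs from compound 2 in one place: 4-(trifluoromethyl)phenyl in place of 2,6-dichlorophenyl on a saturated ring carbon. Going by the values given here, no pair of measured compounds shows this kind of exchange, so no measured step tells how large its effect is in this assay. Among the compounds with values here, with only the three numbers above and no comparable step among them, the expected step is small, in no clear direction, and not beyond the scatter. Compound 4 is therefore expected to give 20% in this assay, with a range from 5% to 40%. The step of a number 4.1 percentage points higher from compound 2 to compound 4 (within the scatter) that this estimate implies is expected to stay within the scatter.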

Compound 4, a percentage reported as inhibition, at one concentration (the size of the read-out at that concentration, not a potency): 3.4%
Compound 4: middle estimate off by 16.6 percentage points, on the high side, outside the stated range (below it).
By their numbers in this assay, from the lowest: compounds 4 and 1 (each within the scatter of the next); then compounds 2 and 3 (each within the scatter of the next).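

In this assay, the exchange of 2,6-dichlorophenyl for 4-(trifluoromethyl)phenyl on the saturated ring carbon brings a number 12.5 percentage points lower from compound 2 to compound 4 (beyond the scatter). Going by these compounds alone, this is the first single exchange that can be read, and it shows that the read-out at this position depends on which aryl group is attached. The change replaces both chlorines and adds a trifluoromethyl group at once, so this one step does not separate the two, and nothing measured here explains its size.

From the compounds shown here alone, it remains open whether the loss of the chlorines or the arrival of the trifluoromethyl group accounts for the step. Going by these compounds, it is also open how a plain phenyl, or a phenyl carrying an amine or a carboxylic acid, would read at this ring carbon.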